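Swapping Pyridin-4-yl for 2-Methylphenyl on a Carbonyl Carbon

The compounds below may be only part of what the source reports. "The series", "measured", "known", "first", "only" and "open" are said of these compounds alone.

Of the compounds shown here, three built on one shared core have been measured in an assay on MDA-MB-231 cells for binding affinity to C-X-C chemokine receptor type 4 (Homo sapiens), read by immunofluorescence and microscopy, with stated times of 10 min and 30 min; a higher number here means that more compound is needed for the effect, a lower number that less compound is needed. Compound 1 `Cc1ccc(S(=O)(=O)NCc2ccc(CNC(=O)c3ccncc3)cc2)cc1` gives 10 nM, and compound 2 `O=C(NCc1ccc(CNS(=O)(=O)c2ccccc2)cc1)c1ccncc1`, which differs from it only by a hydrogen in place of a methyl on an aromatic carbon, gives 10 nM; the step of no change at the digits printed from compound 1 to compound 2 (within the scatter). Compound 3 `Cc1ccc(S(=O)(=O)NCc2ccc(CNC(=O)c3cccc(C)c3)cc2)cc1` gives 1000 nM, and the step of a 100-fold higher number from compound 1 to compound 3 (2.00 log units; beyond the scatter). Compound 2 thus stands level with compound 1, the two together giving the lowest numbers of the three, with compound 3 furthest away.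

Compound 4 `Cc1ccccc1C(=O)NCc1ccc(CNS(=O)(=O)c2ccccc2)cc1` has not yet been measured. Relative to compound 2 it carries 2-methylphenyl in place of pyridin-4-yl on a carbonyl carbon. Among the compounds with values here, only one measured step bears on this change, and it also exchanged pyridin-4-yl for a methyl-bearing phenyl on a carbonyl carbon: a 100-fold higher number from compound 1 to compound 3 (2.00 log units; beyond the scatter). Within the data shown here, no measured pair shows how 2-methylphenyl compares with 3-methylphenyl, so the exact position of the methyl remains an open point. A step in the same direction and of similar size is expected, namely a 100-fold higher number from compound 2 to compound 4 (2.00 log units; beyond the scatter) in this assay. Compound 4 is therefore estimated to give about 1000 nM, with a likely range from 200 nM to 5000 nM.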

Compound 4, effective concentration (reported as EC, without a stated level of effect): 1 nM
Compound 4: the middle estimate sits 1000-fold (3.00 log units) above what was measured; the whole stated range lies above it.
By their numbers in this assay, from the lowest: compound 4; then compounds 1 and 2 (each within the scatter of the next); then compound 3.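

In this assay, the exchange of pyridin-4-yl for 2-methylphenyl on a carbonyl carbon gives a 10-fold lower number from compound 2 to compound 4 (1.00 log units; beyond the scatter), whereas 3-methylphenyl in that place gave a 100-fold higher number from compound 1 to compound 3 (2.00 log units; beyond the scatter), so the two exchanges run in opposite directions. Losing pyridin-4-yl therefore does not by itself raise the number: here a ring of carbon only, with no hydrogen-bond acceptor counted in the group, goes with a lower number than compound 2 gives, so the ring nitrogen is not needed for a low number in this compound. No measurement of any property of these groups is at hand to account for this reversal.

The two exchanges differ both in where the methyl sits on the phenyl ring and in the methyl that compound 1 and compound 3 carry but compound 2 and compound 4 lack, and no pair shown separates these two differences. Also open, as far as these compounds go, is how an unsubstituted phenyl, a 2-chlorophenyl or a 2-methoxyphenyl would read in this place, which would show whether the result is tied to the methyl itself.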